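The source may report more compounds than this note shows. Statements on the series, on what has been measured and on what is new or still open speak of the compounds shown alone.

Measured so far in an ADME assay on HT-29 cells (Homo sapiens) for cytotoxicity, read by MTT assay, with a stated time of 72 h; a lower number here means a stronger inhibitor, a higher number a weaker inhibitor:
Compound 1 `COc1ccc(C2=C(c3cc(OC)c(OC)c(OC)c3)C(=O)C(OC(C)=O)C2)cc1OC(C)C`: compound 1 gives > 100 ug/mL, a limit of the assay.
Compound 2 `C=CCOc1cc(C2=C(c3cc(OC)c(OC)c(OC)c3)C(=O)C(O)C2)ccc1OC`: compound 2 gives > 100 ug/mL, likewise a limit.
Compound 3 `COc1ccc(OC)c(C2=C(c3cc(OC)c(OC)c(OC)c3)C(=O)CC2O[SiH2]C(C)(C)C)c1`: compound 3 gives 5 ug/mL.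

Compound 2 stands at the limit of > 100 ug/mL in this assay, at which 2 of the 3 values shown sit; for it only a limit is known, and no number. For the measured compounds named here, compound 3 differs from compound 2 in several places at once, so the two values together give no single measured step.

Compound 4 `COc1ccc(C2=C(c3cc(OC)c(OC)c(OC)c3)C(=O)C(O)C2)cc1NC(=O)c1ccccc1` carries benzamido in place of allyloxy on an aromatic carbon. Going by the values given here, no measured step covers this change, so the step of an at least 1.2-fold lower number from compound 2 to compound 4 (0.09 log units; that floor lies within the scatter) is expected to stay within the usual scatter, in no particular direction, with a fair chance that only a limit is reported again. Compound 4 is expected at 80 ug/mL, within a range of 20 ug/mL to 200 ug/mL.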

Compound 4, half-maximal inhibitory concentration: > 100 ug/mL
Compound 4 was reported as a limit; the forecaster's own chance of this, stated with the estimate: 50%; at least 1.2-fold (0.09 log units) between middle value and limit.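

Compound 4, like compound 2, is reported only as a limit, so no step can be read between them. The compounds shown leave open what benzamido in place of allyloxy does to the cytotoxicity read-out.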